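This account rests on a few compounds, and the source may have more. Where it says the series, first, only, none or still open, it means among the compounds named here.

Measured compounds:
- compound 1 `CNC(=O)C[C@@H]1C[C@@H](c2ccc(Cl)c(Cl)c2)[C@H](NC(=O)c2cc(-c3c(Cl)cnn3C)c(Cl)o2)CN1`: 2.64 nM in an assay for inhibition of RAC-alpha serine/threonine-protein kinase (Homo sapiens), read by HTRF, with a stated time of 1 h; on this read-out lower numbers stand for stronger inhibition and higher numbers for weaker inhibition
- compound 2 `Cn1ncc(Cl)c1-c1cc(C(=O)NC2CNCCC2c2ccc(C(F)(F)F)cc2)oc1Cl`: 7.2 nM in this assay

Compound 1 holds the lowest of the two numbers; compound 2 lies above it by a gap beyond the usual scatter. Compound 3 `Cn1ncc(Cl)c1-c1cc(C(=O)N[C@@H]2CN[C@H](CCn3cncn3)C[C@H]2c2ccc(Cl)c(Cl)c2)oc1Cl` is not yet measured. It differs from compound 1 by (1H-1,2,4-triazol-1-yl)methyl in place of methylcarbamoyl on a saturated chain carbon bound to a saturated ring carbon. For the measured compounds named here, no measured pair shows this change, so the expected step is modest, toward a somewhat higher number, and is set at a 1.9-fold higher number from compound 1 to compound 3 (0.28 log units; within the scatter), which may still fall within the scatter. Compound 3 is therefore expected to give 5 nM, with a range from 1.5 nM to 16 nM.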

Compound 3, half-maximal inhibitory concentration: 4.47 nM
Compound 3: the middle estimate sits 1.1-fold (0.05 log units) above what was measured; the range from low to high includes it.
By their numbers in this assay, from the lowest: compounds 1, 3 and 2 (each within the scatter of the next, the first and the last beyond it).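

In this assay, (1H-1,2,4-triazol-1-yl)methyl in place of methylcarbamoyl on a saturated chain carbon bound to a saturated ring carbon gives a 1.7-fold higher number from compound 1 to compound 3 (0.23 log units; within the scatter). This place therefore accepts an aromatic ring with 0 hydrogen-bond donors in place of an amide carrying 1, with the two values staying within the scatter. Nothing at hand bears on why the two groups read alike. Open, on these data alone, is whether other groups at this place, such as a primary amine, a carboxylic acid or a longer chain ending in the same triazole, stay in this range.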